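Triazole nitrogen substituent: from compound 2 to compound 4

A few compounds are considered here, and "the series" means these few. Any claim that something is new, unique, unknown or untested is made for them only; others in the source may bear on it.

Measured compounds in a functional assay on CFPAC-1 cells (Homo sapiens) for antiproliferative activity, read by MTT assay, with a stated time of 72 h; a lower number here means a stronger inhibitor, a higher number a weaker inhibitor:
- compound 1 `O=c1nc2oc(CCCCl)cc2cn1Cc1cn(-c2ccccc2F)nn1` gives 81800 nM
- compound 2 `O=c1nc2oc(CCCCl)c(C#CCCCCl)c2cn1Cc1cn(Cc2ccccc2)nn1` gives 32800 nM
- compound 3 `O=c1nc2oc(CCCCl)cc2cn1Cc1cn(Cc2ccccc2)nn1` gives 23500 nM

Compound 2 stands second highest of the three numbers in this assay; it sits close to compound 3, the step of a 1.4-fold lower number from compound 2 to compound 3 (0.14 log units; within the scatter) being within the scatter, while compound 1 lies further off, beyond the scatter.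

Compound 4 `O=c1nc2oc(CCCCl)c(C#CCCCCl)c2cn1Cc1cn(-c2ccc(Cl)cc2)nn1` differs from compound 2 in one place: 4-chlorophenyl in place of benzyl on an aromatic nitrogen.

Within the data shown here, one measured step bears on this change. From compound 1 to compound 3 a benzyl group replaced a 2-fluorophenyl group on the same aromatic nitrogen, and the number fell: a 3.5-fold lower number from compound 1 to compound 3 (0.54 log units; beyond the scatter). The change from compound 2 to compound 4 runs the other way, an aryl group entering where benzyl stood, so the number is expected to rise by a modest amount in this assay. Among the measured compounds shown here, the 4-chlorophenyl group is not identical to 2-fluorophenyl, and only one such pair is available, so the expectation is loose.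

The step from compound 2 to compound 4 is estimated as a 2.3-fold higher number from compound 2 to compound 4 (0.36 log units; beyond the scatter) in this assay. For compound 4 the estimate in this assay is 75000 nM, with a range from 30000 nM to 180000 nM.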

Compound 4, half-maximal inhibitory concentration: > 100000 nM
Compound 4 ended at the assay's limit; the forecaster's own chance of this, stated with the estimate: 15%; at least 1.3-fold (0.12 log units) between middle value and limit.
By their numbers in this assay, from the lowest: compounds 3 and 2 (each within the scatter of the next); then compound 1. At a limit, above all of these: compound 4.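

In this assay, 4-chlorophenyl in place of benzyl on the aromatic nitrogen gives an at least 3.0-fold higher number from compound 2 to compound 4 (0.48 log units; beyond the scatter), which extends the picture to a compound carrying 5-chloropent-1-yn-1-yl, a chain absent from the earlier pair at this nitrogen. The reading for compound 4, > 100000 nM, is a limit of this assay and not a number, so the step has a lower bound but no upper one: the limit of > 100000 nM in this assay, at which 1 of the 4 values shown sits.

Both pairs that differ at this nitrogen now point the same way, with the benzyl member lower in each, compound 3 against compound 1 and compound 2 against compound 4, and neither pair goes against this, though the two aryl groups differ and the pairs differ in the rest of the structure.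

The compounds shown leave open whether the rise follows from the aryl group sitting directly on the nitrogen or from the particular halogen on it, a question that an unsubstituted phenyl or a 4-chlorobenzyl group would address. They also leave open how an amine-bearing chain or a carboxylic acid at this nitrogen would read.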